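Pyrazine to pyridazine on the hydrazide carbonyl

This account rests on a few compounds, and the source may have more. Where it says the series, first, only, none or still open, it means among the compounds named here.

The series shares one core, a hydrazone of an ortho-hydroxyacetophenone joined to an aryl carbonyl, and was tested in a toxicity assay (H9c2 cells) for cytotoxicity, with Rattus norvegicus as the target, read by neutral red uptake, with a stated time of 72 h; a higher number here means a weaker inhibitor, a lower number a stronger inhibitor. Compound 1 `C/C(=N\NC(=O)c1ccc(-c2ccccc2)cc1)c1ccccc1O` gives in this assay a value of > 100000 nM, which is a limit of the assay and not a number. Compound 2 `C/C(=N\NC(=O)c1cccc2ccccc12)c1ccccc1O` gives in this assay > 200000 nM, again a limit rather than a number. Among the compounds with values here, compound 3 `C/C(=N\NC(=O)c1cnccn1)c1ccccc1O` is the one compound with a measured figure, giving in this assay 41200 nM. It is therefore the only point from which a step can be counted. The two other compounds stand at limits (the limit of > 100000 nM in this assay, at which 1 of the 3 values shown sits, and (the limit of > 200000 nM in this assay, at which 1 of the 3 values shown sits)).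

Compound 4 `C/C(=N\NC(=O)c1ccnnc1)c1ccccc1O` differs from compound 3 by one change: pyridazin-4-yl in place of pyrazin-2-yl on a carbonyl carbon, in words pyridazin-4-yl in place of pyrazin-2-yl on a carbonyl carbon. Within the data shown here, no measured step of this kind exists among the compounds above. Since the two groups are the same atoms joined differently, the step from compound 3 to compound 4 is expected to stay within the scatter, with no clear direction, so that a 1.0-fold lower number from compound 3 to compound 4 (0.01 log units; within the scatter) is the estimated change. Compound 4 is therefore expected to give about 40000 nM in this assay, somewhere between 15000 nM and 120000 nM.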

Compound 4, half-maximal inhibitory concentration: 22800 nM
Beside the measured number, compound 4's estimate is 1.8-fold (0.24 log units) above it; the measured number falls inside the stated range.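

Within the data shown here, the exchange of pyrazin-2-yl for pyridazin-4-yl on a carbonyl carbon gives a 1.8-fold lower number from compound 3 to compound 4 (0.26 log units; within the scatter) in this assay and is the first step that can be counted at all. The two groups hold the same atoms joined differently, and at this place that rearrangement alone does not move the number beyond the usual scatter. Nothing known here bears on why the two values lie where they do.

Compounds 1 and 2 stand at limits of the assay and not at numbers, so steps involving them cannot be read. On these data alone, it remains open whether a pyrimidin-5-yl group, or a pyridazin-4-yl group carrying an amine, on the same carbonyl carbon would also stay within the scatter.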